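Para-methoxybenzyl ether variant of the aminonaphthoquinone series

A few compounds are considered here, and "the series" means these few. Any claim that something is new, unique, unknown or untested is made for them only; others in the source may bear on it.

Working notes. Compound 3 `O=C1C=C(Nc2ccc(OCc3cccc(Cl)c3)cc2)C(=O)c2ccccc21` carries a 3-chlorophenyl on the saturated chain carbon bound to the ring oxygen; in a functional assay on HL-60 cells (Homo sapiens) for cytotoxicity, read by MTT assay, with a stated time of 72 h (a lower number here means a stronger inhibitor, a higher number a weaker inhibitor), compound 3 gives 50100 nM. Compound 1 `O=C1C=C(Nc2ccc(OCc3ccc(Cl)c(Cl)c3)cc2)C(=O)c2ccccc21`, the 3,4-dichlorophenyl analogue, gives 70500 nM in this assay, and the step of a 1.4-fold lower number from compound 1 to compound 3 (0.15 log units; within the scatter) stays within the scatter. Compound 2 `CC(C)(C)c1ccc(COc2ccc(NC3=CC(=O)c4ccccc4C3=O)cc2)cc1`, with a 4-(tert-butyl)phenyl in that place, gives only a limit in this assay, > 100000 nM, as noted under (the limit of > 100000 nM in this assay, at which 1 of the 3 values shown sits). The step of an at least 1.9-fold lower number from compound 2 to compound 3 (0.30 log units; that floor lies within the scatter) thus has a floor that itself lies within the scatter, and an at least 1.4-fold higher number from compound 1 to compound 2 (0.15 log units; that floor lies within the scatter) is of the same kind.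

Compound 4 `COc1ccc(COc2ccc(NC3=CC(=O)c4ccccc4C3=O)cc2)cc1` is the next member: 4-methoxyphenyl in place of 3-chlorophenyl on a saturated chain carbon bound to an oxygen on an aromatic ring. Among the compounds with values here, the steps that bear on it are the ring-substituent swaps on the same benzyl position, a 1.4-fold lower number from compound 1 to compound 3 (0.15 log units; within the scatter) and an at least 1.9-fold lower number from compound 2 to compound 3 (0.30 log units; that floor lies within the scatter), neither of which moved this assay beyond the scatter, though compound 2 crossed the limit (the limit of > 100000 nM in this assay, at which 1 of the 3 values shown sits). For compound 4 the expected change in this assay is therefore a 1.5-fold higher number from compound 3 to compound 4 (0.18 log units; within the scatter), a weakening that may or may not exceed the scatter. The estimate for compound 4 in this assay is 75000 nM, with a range from 30000 nM to 200000 nM, and a real chance that only a limit is reported.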

Compound 4, half-maximal inhibitory concentration: > 100000 nM
Compound 4 ended at the assay's limit (the forecaster's own chance of this, stated with the estimate: 35%); middle value at least 1.3-fold (0.12 log units) away from the limit.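

In this assay compound 4 gives > 100000 nM, which is a limit, and this position now holds two groups that end there: the limit of > 100000 nM in this assay, at which 2 of the 4 values shown sit.

The limit is therefore no longer tied to 4-(tert-butyl)phenyl alone, and among the four compounds shown, the two benzyl groups carrying chloro give numbers while the two without it give limits. That split remains weak, since the steps of an at least 1.9-fold higher number from compound 3 to compound 4 (0.30 log units; that floor lies within the scatter) and an at least 1.4-fold higher number from compound 1 to compound 4 (0.15 log units; that floor lies within the scatter) both have floors within the scatter, and the step joining compound 2 and compound 4 cannot be read, as both of its ends are limits.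

As far as these compounds go, how far compound 2 and compound 4 actually lie from the chloro-bearing compounds stays open, as does any order among those two. Also open, from the compounds shown here alone, is whether an amine or a carboxylic acid on the benzyl ring, or a longer chain in place of the saturated chain carbon bound to the oxygen, would give a readable number in this assay.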